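Oxanyl to isobutylpiperazinyl on the phenylbutyl series

This account rests on a few compounds, and the source may have more. Where it says the series, first, only, none or still open, it means among the compounds named here.

Compound 2 `O=C(NCCCCc1ccccc1)n1c(=O)oc2cc(C3CCOCC3)ccc21` stands lowest of the three numbers in an assay on HEK293 cells for inhibition of acid ceramidase (Homo sapiens), read by fluorescence, with stated times of 10 min and 3 h (on this read-out lower numbers stand for stronger inhibition and higher numbers for weaker inhibition), at 68 nM. For the measured compounds named here, compound 1 `CC(C)CNC(=O)n1c(=O)oc2cc(C3CCCCN3C)ccc21` gives 1010 nM and compound 3 `CC(C)CNC(=O)n1c(=O)oc2cc(C3CCCN(C)C3)ccc21` gives 1750 nM; the one single-place step measured, a 1.7-fold higher number from compound 1 to compound 3 (0.24 log units; within the scatter), lies within the scatter. Compound 4 `CC(C)CN1CCN(c2ccc3c(c2)oc(=O)n3C(=O)NCCCCc2ccccc2)CC1` carries 4-isobutylpiperazin-1-yl in place of oxan-4-yl on an aromatic carbon. Going by the values given here, no measured step bears directly on this change: the step between compound 1 and compound 3 swaps one nitrogen-containing ring for another under a different amide chain, and compound 2 differs from both in two places. The expectation is therefore weak, and a modest step towards a higher number is estimated, a 2.9-fold higher number from compound 2 to compound 4 (0.47 log units; beyond the scatter), since the two compounds with nitrogen-containing rings sit higher than compound 2. Compound 4 is expected near 200 nM, within 50 nM to 800 nM.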

Compound 4, half-maximal inhibitory concentration: 127 nM
Beside the measured number, compound 4's estimate is 1.6-fold (0.20 log units) above it; the measured number falls inside the stated range.
By their numbers in this assay, from the lowest: compounds 2 and 4 (each within the scatter of the next); then compounds 1 and 3 (each within the scatter of the next).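

In this assay the change from oxan-4-yl to 4-isobutylpiperazin-1-yl gives a 1.9-fold higher number from compound 2 to compound 4 (0.27 log units; within the scatter), so on the phenylbutyl series this aromatic carbon carries either ring without a step beyond the scatter. The earlier step, a 1.7-fold higher number from compound 1 to compound 3 (0.24 log units; within the scatter), compared only two 1-methylpiperidinyl attachments on the isobutyl amide chain and did not cover the phenylbutyl series. No measured evidence explains this result.

Open, as far as these compounds go, is whether a smaller group on the piperazine nitrogen, such as methyl, or a carboxylic acid on that nitrogen's chain keeps the number in this range. Also open, from the compounds shown here alone, is how 4-isobutylpiperazin-1-yl behaves on the isobutyl amide chain.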